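A Phenyl Takes the Place of a Methyl

The compounds below may be only part of what the source reports. "The series", "measured", "known", "first", "only" and "open" are said of these compounds alone.

In a functional assay on the whole organism with Rattus norvegicus as the target (a lower number here means a stronger inhibitor, a higher number a weaker inhibitor), three compounds have been measured so far. Compound 1 `CC(C)c1nn(-c2ccccc2)c(-c2ccc(F)cc2)c1/C=C/[C@@H](O)C[C@@H](O)CC(=O)O` gives 8 nM and compound 2 `CC(C)c1nn(-c2cnccn2)c(-c2ccc(F)cc2)c1/C=C/[C@@H](O)C[C@@H](O)CC(=O)O` gives 64 nM while compound 3 `Cc1cc(-c2ccc(F)cc2)c(/C=C/[C@@H](O)C[C@@H](O)CC(=O)O)c(C(C)C)n1` gives 17 nM as the middle of the three numbers. Compound 4 `CC(C)c1nc(-c2ccccc2)cc(-c2ccc(F)cc2)c1/C=C/[C@@H](O)C[C@@H](O)CC(=O)O` differs from compound 3 in one place, described as phenyl in place of methyl on an aromatic carbon with phenyl in place of methyl on an aromatic carbon, next to the ring nitrogen. Among the compounds with values here, no measured step makes this exchange. The only one with any bearing is an 8.0-fold higher number from compound 1 to compound 2 (0.90 log units; beyond the scatter) with pyrazin-2-yl in place of phenyl on an aromatic nitrogen, and it comes from a different core. Compound 1 shows that a core carrying phenyl can read 8 nM in this assay so a small step toward a lower number is expected, near the edge of the scatter and with little support. The estimated move is a 1.9-fold lower number from compound 3 to compound 4 (0.28 log units; within the scatter) and it remains tentative. For compound 4 the expected value is 9 nM within an estimated range from 3 nM to 30 nM as the likely span.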

Compound 4, half-maximal inhibitory concentration: 16 nM
The estimate for compound 4 lay 1.8-fold (0.25 log units) below the measured number; the range from low to high includes it.
By their numbers in this assay, from the lowest: compounds 1, 4 and 3 (each within the scatter of the next, the first and the last beyond it); then compound 2.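

In this assay the carbon next to the ring nitrogen carries phenyl in place of methyl with a 1.1-fold lower number from compound 3 to compound 4 (0.03 log units; within the scatter) as the whole step, so at this position the two groups cannot be told apart. Within the data shown here, until now the only reading on an exchange of aromatic groups was an 8.0-fold higher number from compound 1 to compound 2 (0.90 log units; beyond the scatter) on an aromatic nitrogen of a different core, and it said nothing about this carbon. No available measurement offers an explanation for this result.

The compounds shown leave open whether pyrazin-2-yl at this carbon would raise the number as it does between compound 1 and compound 2. They also leave open whether an amine, a carboxylic acid or a longer alkyl chain would fit here as well as methyl and phenyl do.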